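Chloro for hydroxy on a benzoxazole sulfonamide: the weak end

The source may hold more compounds than are shown below. What is called first, only, known or untested is meant among the compounds shown, and "the series" means these compounds.

Of the compounds shown here, two have been tested so far in an assay on isolated protein for inhibition of malate dehydrogenase, mitochondrial (Sus scrofa), with stated times of 45 min and 30 min; a higher number here means a weaker inhibitor, a lower number a stronger inhibitor. Compound 1 `O=S(=O)(Nc1ccc(-c2nc3ccccc3o2)cc1)c1ccc(Cl)s1` carries a chlorinated thiophene sulfonamide on the shared core. In this assay compound 1 reaches only a limit, > 63000 nM. Compound 2 `O=S(=O)(Nc1ccc2oc(-c3ccccc3)nc2c1)c1ccc(O)cc1` places the sulfonamide on the other side of the shared core and bears a hydroxy on its outer ring. In this assay compound 2 likewise gives only a limit, > 63000 nM. Both values therefore sit at the same point, (the limit of > 63000 nM in this assay, at which 2 of the 2 values shown sit), so neither compound can be placed above or below the other, and compound 2 stands at the weak end of what the assay reports.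

Compound 3 `O=S(=O)(Nc1ccc2oc(-c3ccccc3)nc2c1)c1ccc(Cl)cc1` is the next compound, differing from compound 2 in one place: chloro in place of hydroxy on an aromatic carbon. Within the data shown here, since compound 2 gives only a limit in this assay, no measured step sets a scale for what this change might do, and the prose expects no step beyond the usual scatter, a step that the limit leaves unreadable from compound 2 to compound 3. The estimate for compound 3 in this assay is 80000 nM, between 20000 nM and 300000 nM, with a limit rather than a number the most likely outcome.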

Compound 3, half-maximal inhibitory concentration: > 63000 nM
Compound 3 gave a limit, no number; the forecaster's own chance of this, stated with the estimate: 80%; the middle value lies beyond the limit too.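

In this assay compound 3 gives > 63000 nM, which is a limit and not a number. Compound 2 also stands at a limit, so no step can be read between compound 2 and compound 3. The compounds shown leave open whether any of these structures has a measurable potency, and which group would favour it, as all of them sit at one point: the limit of > 63000 nM in this assay, at which 3 of the 3 values shown sit.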